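The compounds below may be only part of what the source reports. "The series", "measured", "known", "first", "only" and "open" are said of these compounds alone.

In an ADME assay on microsomes from liver (Mus musculus) for metabolic stability, read by HPLC, with a stated time of 4 h (on this read-out higher numbers stand for a longer-lived compound and lower numbers for a shorter-lived compound), compound 1 `CN(C)c1ccc2cc(-c3ccccc3)c(N)nc2c1` gives < 0.1 h, which is a limit of the assay and not a number. Compound 2 `CN(C)c1ccc2cc(-c3ccccc3F)c(N)nc2c1` gives < 0.1 h, which is also a limit. That position is the limit of < 0.1 h in this assay, at which 2 of the 2 values shown sit. Compound 3 `CN(C)c1ccc2cc(-c3ccccc3Cl)c(N)nc2c1` differs from compound 2 by chloro in place of fluoro on an aromatic carbon, ortho to a large group. Within the data shown here, the one measured step that bears on this change is a step that the two limits leave unreadable from compound 1 to compound 2. It gives no size to carry over, so no step beyond the scatter is expected in this assay. The expected step is a step that the limit leaves unreadable from compound 2 to compound 3. For compound 3 the estimate is 0.07 h, with an expected range of 0.03 h to 0.2 h.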

Compound 3, half-life: 0.13 h
Compound 3: the middle estimate sits 1.9-fold (0.27 log units) below what was measured, and the stated range covers the measured number.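

In this assay, among these compounds, chloro in place of fluoro on an aromatic carbon, ortho to a large group, gives the first step at this position with a readable floor: an at least 1.3-fold higher number from compound 2 to compound 3 (0.11 log units; that floor lies within the scatter). Chloro in place of hydrogen at the same place reads alike: an at least 1.3-fold higher number from compound 1 to compound 3 (0.11 log units; that floor lies within the scatter). Neither floor goes beyond the scatter, and most of the series still sits at the bottom of the scale: the limit of < 0.1 h in this assay, at which 2 of the 3 values shown sit.

As far as these compounds go, the full size of both steps stays open, and the steps between limits cannot be read. From the compounds shown here alone, whether methoxy, trifluoromethyl or an amine at this place would lengthen the half-life also stays open.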